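A few compounds are considered here, and "the series" means these few. Any claim that something is new, unique, unknown or untested is made for them only; others in the source may bear on it.

Within the data shown here, in an ADME assay on NIH3T3 cells (Mus musculus) for cytotoxicity, read by MTT assay, with a stated time of 24 h (on this read-out higher numbers stand for weaker inhibition and lower numbers for stronger inhibition), compound 2 `Cc1nnc(SCC(=O)N/N=c2/scc(-c3ccc([N+](=O)[O-])cc3)n2-c2ccccc2)s1` gives 177 ug/mL, the lowest of the two numbers measured so far; compound 1 `Cc1nnc(SCC(=O)N/N=c2/scc(-c3ccccc3)n2-c2ccccc2)s1` gives 197 ug/mL. Among the measured compounds shown here, the single step measured so far, a 1.1-fold lower number from compound 1 to compound 2 (0.05 log units; within the scatter), lies within the scatter. Compound 3 `Cc1nnc(SCC(=O)N/N=c2/scc(-c3ccc(Cl)cc3)n2-c2ccccc2)s1` is the next member and differs from compound 2 by chloro in place of nitro on an aromatic carbon. For the measured compounds named here, no measured step exchanges nitro for chloro, so the only bearing comes from the nitro-for-hydrogen step already measured. Because a 1.1-fold lower number from compound 1 to compound 2 (0.05 log units; within the scatter) moved the number by less than the scatter, the exchange of nitro for chloro is expected to leave the read-out near that of compound 2 as well, with no step beyond the scatter in either direction. The expected step in this assay is a 1.0-fold higher number from compound 2 to compound 3 (0.02 log units; within the scatter). Compound 3 is therefore estimated at 185 ug/mL, with a range from 110 ug/mL to 310 ug/mL.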

Compound 3, half-maximal inhibitory concentration: 253 ug/mL
Compound 3: middle estimate off by 1.4-fold (0.14 log units), on the low side, within the range that was stated.
By their numbers in this assay, from the lowest: compounds 2, 1 and 3 (each within the scatter of the next).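

In this assay, the direct exchange of 4-nitrophenyl to 4-chlorophenyl gives a 1.4-fold higher number from compound 2 to compound 3 (0.16 log units; within the scatter), and chloro in place of hydrogen on the same aromatic carbon gives a 1.3-fold higher number from compound 1 to compound 3 (0.11 log units; within the scatter). This place has now taken a second group, and the exchange of one group for the other also stays inside the scatter, so hydrogen, nitro and chloro are not separated on this read-out in compound 1, compound 2 and compound 3. Nothing at hand accounts for the size of these steps.

On these data alone, whether any group on this aromatic carbon moves the number beyond the scatter remains open, as does the reading of an amine, a carboxylic acid or a longer chain there. Also open, as far as these compounds go, is whether these exchanges would read alike with a change elsewhere on the shared core.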